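The source may report more compounds than this note shows. Statements on the series, on what has been measured and on what is new or still open speak of the compounds shown alone.

Within the data shown here, in an ADME assay on LLC-MK2 cells (Macaca mulatta) for cytotoxicity, read by spectrophotometry and crystal violet staining, with a stated time of 4 days (a lower number here means that less compound is tolerated, a higher number that more compound is tolerated), compound 1 (`CC(C)n1ncc2c(C(=O)Nc3ncccn3)cc(-c3ccsc3)nc21`) gives 50000 nM and compound 3 (`CC(C)n1ncc2c(C(=O)Nc3ccccn3)cc(C3CC3)nc21`) gives 25000 nM, so the only two exact numbers lie within the usual scatter of each other. Compound 2 (`CC(C)n1ncc2c(C(=O)N3CCc4cc(F)ccc43)cc(-c3cccs3)nc21`) gives only a limit of the assay, > 200000 nM. Compound 4 (`CC(C)n1ncc2c(C(=O)Nc3ncccn3)cc(-c3cccs3)nc21`) keeps the core of compound 1 but carries thiophen-2-yl in place of thiophen-3-yl on an aromatic carbon. The two compounds have the same atoms, joined differently. Among the measured compounds shown here, no measured pair shows the effect of this swap, so no change beyond the scatter is expected in this assay on going from compound 1 to compound 4. The expected step, a 1.1-fold higher number from compound 1 to compound 4 (0.04 log units; within the scatter), stays within that scatter. For compound 4 the estimated value is 55000 nM, with an expected range of 20000 nM to 150000 nM.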

Compound 4, half-maximal cytotoxic concentration: 75000 nM
Compound 4: middle estimate off by 1.4-fold (0.13 log units), on the low side; the measured number falls inside the stated range.
By their numbers in this assay, from the lowest: compounds 3, 1 and 4 (each within the scatter of the next, the first and the last beyond it). At a limit, above all of these: compound 2.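

In this assay, among these compounds, thiophen-2-yl in place of thiophen-3-yl on this aromatic carbon, next to the ring nitrogen, gives a 1.5-fold higher number from compound 1 to compound 4 (0.18 log units; within the scatter), the first direct reading of a change at this position. Within that scatter, the two thiophene attachments cannot be told apart in this assay. Nothing measured here gives a reason for this result. As far as these compounds go, whether an amine or a carboxylic acid on this carbon would move the number beyond the scatter stays open. So does whether the same swap would give a similar step with a different amide on the shared core.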